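A few compounds are considered here, and "the series" means these few. Any claim that something is new, unique, unknown or untested is made for them only; others in the source may bear on it.

Measured in a functional assay on HCT-116 cells (Homo sapiens) for inhibition; a lower number here means a stronger inhibitor, a higher number a weaker inhibitor:
- Compound 1 (`COCCOc1cc(/C=C/c2ccc3ccccc3c2)ccc1OC`) : > 5000 nM, a limit and not a number
- Compound 2 (`COCCOc1cc(/C=C\c2ccc3ccccc3c2)ccc1OC`) : 2990 nM
- Compound 3 (`Cc1ccc(/C=C\c2ccc3ccccc3c2)cc1`) : > 5000 nM, a limit and not a number

Among the compounds with values here, compound 2 is the only compound here with a true number, 2990 nM. The results for compound 1 and compound 3 are limits of the assay. Moving on to compound 4 (`COc1ccc(/C=C\c2ccc3ccccc3c2)cc1[N+](=O)[O-]`) puts nitro in place of 2-methoxyethoxy on an aromatic carbon, ortho to a methoxy group: nitro in place of 2-methoxyethoxy on an aromatic carbon.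

Within the data shown here, only one measured step exists, an at least 1.6-fold lower number from compound 1 to compound 2 (0.22 log units; that floor lies within the scatter), and it says little about swapping a group because of the fact that compounds 1 and 2 differ only in the configuration as drawn. From the compounds shown here alone, its true size also stays open because of the limit of > 5000 nM in this assay, at which 2 of the 3 values shown sit. Among the measured compounds shown here, no measured step covers the change at this carbon, so no step beyond the scatter is expected in this assay, and a result at the limit would be no surprise. The expected change is a 1.0-fold higher number from compound 2 to compound 4 (0.00 log units; within the scatter). For compound 4 the estimated value is 3000 nM, with an expected range from 700 nM to 5000 nM.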

Compound 4, half-maximal inhibitory concentration: > 20000 nM
Compound 4: only a limit was reported; the forecaster's own chance of this, stated with the estimate: 45%; middle value at least 6.6-fold (0.82 log units) from the limit.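

In this assay, nitro in place of 2-methoxyethoxy on the aromatic carbon ortho to a methoxy group gives an at least 6.6-fold higher number from compound 2 to compound 4 (0.82 log units; beyond the scatter). The earlier compounds shown here offered no measured change at this carbon, and this step shows that the group there can matter in this assay, since it lies beyond the scatter. Compound 4 gives > 20000 nM, which is a limit and not a number, so the step is only a floor and its true size stays open: the limit of > 20000 nM in this assay, at which 1 of the 4 values shown sits.

With a single replacement compared, the result cannot separate the loss of the 2-methoxyethoxy chain from the arrival of nitro, and an amine or a longer ether chain at this carbon would help tell these apart. Within the data shown here, the role of the double bond's configuration also stays unsettled, and its only reading is an at least 1.6-fold lower number from compound 1 to compound 2 (0.22 log units; that floor lies within the scatter).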